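Changing the aromatic group on the amide carbonyl

The source may hold more compounds than are shown below. What is called first, only, known or untested is meant among the compounds shown, and "the series" means these compounds.

Among the measured compounds shown here, in a functional assay on A2780 cells (Homo sapiens) for inhibition, read by sulforhodamine B assay, with a stated time of 72 h (a lower number here means a stronger inhibitor, a higher number a weaker inhibitor), compound 2 (`O=C(NCc1ccc(S(=O)(=O)N2CCCCC2)cc1)c1cnc2nccn2c1`) gives 130 nM, the lower of the two numbers so far, and compound 1 (`O=C(NCc1ccc(S(=O)(=O)N2CCCCC2)cc1)c1cc2cnccc2s1`) gives 1600 nM. Compound 3 (`O=C(NCc1ccc(S(=O)(=O)N2CCCCC2)cc1)c1ccn2ccnc2c1`) is unmeasured and keeps the rest of compound 2, with this change on the carbonyl carbon: a group of 9 heavy atoms (7 carbon, 2 nitrogen; one five-membered aromatic ring with 2 hetero atoms, one six-membered aromatic ring with 1 hetero atom) in place of a group of 9 heavy atoms (6 carbon, 3 nitrogen; one five-membered aromatic ring with 2 hetero atoms, one six-membered aromatic ring with 2 hetero atoms), on a carbonyl carbon. For the measured compounds named here, one measured step bears on it, a 12-fold lower number from compound 1 to compound 2 (1.09 log units; beyond the scatter), a large step from an exchange at the same carbonyl carbon. Going by the values given here, that single step shows that the number in this assay can move far with this group, but no measured pair isolates the present change. Compound 3 retains the five-membered aromatic ring with 2 hetero atoms of compound 2, so a smaller move than that step is expected, tentatively upward. The expected step is a 2.2-fold higher number from compound 2 to compound 3 (0.33 log units; beyond the scatter). The estimate for compound 3 is 280 nM, with an expected range of 60 nM to 1300 nM.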

Compound 3, half-maximal inhibitory concentration: > 10000 nM
Compound 3: no number, only a limit; the forecaster's own chance of this, stated with the estimate: 3%; middle value at least 35-fold (1.55 log units) from the limit.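

In this assay compound 3 gives only a limit, not a number: the limit of > 10000 nM in this assay, at which 1 of the 3 values shown sits. Even so, the exchange on the carbonyl carbon gives an at least 76-fold higher number from compound 2 to compound 3 (1.88 log units; beyond the scatter), so a six-membered aromatic ring with 1 hetero atom in place of one with 2 hetero atoms can cost nearly all of the activity, although the five-membered aromatic ring with 2 hetero atoms is kept. The result also places this group behind the sulfur-containing group, with an at least 6.2-fold higher number from compound 1 to compound 3 (0.79 log units; beyond the scatter), so the position discriminates sharply among bicyclic groups of equal heavy-atom count.

The compounds shown do not separate the loss of the ring nitrogen from the different arrangement of the two rings. On these data alone, whether an amine or a methoxy group on the six-membered ring would recover activity remains open.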